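The source may hold more compounds than are shown below. What is called first, only, known or untested is meant among the compounds shown, and "the series" means these compounds.

Within the data shown here, compound 2 `CC/C(=C(/c1ccc(/C=C/C(=O)O)cc1)c1ccc2[nH]ncc2c1Cl)c1ccccc1` holds the lowest number of the two measured so far in a functional assay on MCF7 cells (Homo sapiens) for cytotoxicity, read by CellTiter-Glo, with a stated time of 5 days; on this read-out lower numbers stand for stronger inhibition and higher numbers for weaker inhibition: compound 2 gives 1.6 nM, while compound 1 `CC/C(=C(/c1ccc(/C=C/C(=O)O)cc1)c1cc(C)c2[nH]ncc2c1)c1ccccc1` gives 59 nM. Among the measured compounds shown here, the one measured step, a 37-fold lower number from compound 1 to compound 2 (1.57 log units; beyond the scatter), came from a 4-chloro-1H-indazol-5-yl in place of a 7-methyl-1H-indazol-5-yl on a double-bonded chain carbon bound to an aromatic carbon and a double-bonded chain carbon.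

Compound 3 `CC/C(=C(/c1ccc(/C=C/C(=O)O)cc1)c1cc(Cl)c2[nH]ncc2c1)c1ccccc1` differs from compound 2 by 7-chloro-1H-indazol-5-yl in place of 4-chloro-1H-indazol-5-yl on a double-bonded chain carbon bound to an aromatic carbon and a double-bonded chain carbon. For the measured compounds named here, that step changes where the chlorine sits but not what it is, and no measured pair isolates the position alone: the step from compound 1 to compound 2 moved the substituent and swapped methyl for chlorine at once, so it bears on the question only loosely. Compound 3 carries its chlorine where compound 1 carries its methyl, so a number nearer that of compound 1 than that of compound 2 is expected, with the step of a 16-fold higher number from compound 2 to compound 3 (1.19 log units; beyond the scatter) expected in this assay. Compound 3 is therefore estimated at 25 nM, with a range from 6 nM to 110 nM.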

Compound 3, half-maximal inhibitory concentration: 56 nM
Beside the measured number, compound 3's estimate is 2.2-fold (0.35 log units) below it; the measured number falls inside the stated range.
By their numbers in this assay, from the lowest: compound 2; then compounds 3 and 1 (each within the scatter of the next).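

With the atoms unchanged and only the chlorine moved, 7-chloro-1H-indazol-5-yl in place of 4-chloro-1H-indazol-5-yl gives a 35-fold higher number from compound 2 to compound 3 (1.54 log units; beyond the scatter) in this assay, so the placement of the chlorine alone can carry a large step, which the earlier pair could not show because it changed both the placement and the group. Chloro in place of methyl on an aromatic carbon gives a 1.1-fold lower number from compound 1 to compound 3 (0.02 log units; within the scatter), so in this assay the two 7-substituted indazolyl groups cannot be told apart by their numbers. Across these three compounds, the large difference therefore follows the placement of the substituent and not the swap of methyl for chlorine, although no measurement here says why the placement matters.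

The compounds shown leave open how 4-methyl-1H-indazol-5-yl, 4-fluoro-1H-indazol-5-yl or unsubstituted 1H-indazol-5-yl would compare, and so whether the low number of compound 2 depends on chlorine specifically or on any group at that place. They also leave open whether the same large step would appear if an amide stood in place of the carboxylic acid on the shared core.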